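The compounds below may be only part of what the source reports. "The series", "measured", "known", "first", "only" and "open" are said of these compounds alone.

Compound 1, `CC(C)S(=O)(=O)NC(=O)c1ccc(Nc2nc(NC3(c4ccc(Cl)cc4)CC3)nc(OCC(F)(F)F)n2)cc1`: in a physicochemical assay for permeability, using PAMPA, at pH 7.4 (on this read-out lower numbers stand for lower permeability and higher numbers for higher permeability), compound 1 gives 31 nm/s.
Compound 2, `CC(C)NCCS(=O)(=O)NC(=O)c1ccc(Nc2nc(NC3(c4ccc(Cl)cc4)CC3)nc(OCC(F)(F)F)n2)cc1`: in this assay compound 2 gives 45 nm/s.

Among the measured compounds shown here, compound 2 holds the higher of the two numbers so far, but its nearest neighbour is compound 1, and the step from compound 1 to compound 2 amounts to a 1.5-fold higher number from compound 1 to compound 2 (0.16 log units; within the scatter), so the two compounds cannot be told apart on this read-out.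

Compound 3, `CCS(=O)(=O)NC(=O)c1ccc(Nc2nc(NC3(c4ccc(Cl)cc4)CC3)nc(OCC(F)(F)F)n2)cc1`, has not yet been measured. It differs from compound 2 in one place: hydrogen in place of isopropylamino on a saturated chain carbon, two bonds along the chain from a sulfonyl sulfur. For the measured compounds named here, the only measured step that bears on this is the one from compound 1 to compound 2, where the same isopropylamino-bearing chain was introduced and gave a 1.5-fold higher number from compound 1 to compound 2 (0.16 log units; within the scatter). Removing that group again would, by this one comparison, be expected to give a step of about the same small size in the opposite direction, if any, with nothing beyond the scatter anticipated.

Compound 3 is therefore estimated at 33 nm/s, with a range from 15 nm/s to 70 nm/s, which corresponds to an expected step of a 1.4-fold lower number from compound 2 to compound 3 (0.13 log units; within the scatter).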

Compound 3, apparent permeability: 28 nm/s
Estimate against measurement, compound 3: 1.2-fold (0.07 log units) above; measured number inside the range.
By their numbers in this assay, from the lowest: compounds 3, 1 and 2 (each within the scatter of the next).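

Taking isopropylamino off the saturated chain carbon, two bonds along the chain from the sulfonyl sulfur, removes 4 heavy atoms, including 1 hydrogen-bond donor and 1 hydrogen-bond acceptor, yet this assay shows only a 1.6-fold lower number from compound 2 to compound 3 (0.21 log units; within the scatter). Among the compounds shown here, exchanging methyl for hydrogen on the saturated chain carbon bound to a saturated chain carbon and a sulfonyl sulfur gives a 1.1-fold lower number from compound 1 to compound 3 (0.04 log units; within the scatter), so the isopropyl, ethyl and 2-(isopropylamino)ethyl groups on the sulfonyl sulfur cannot be told apart on this read-out, where the earlier compounds offered only one such comparison. No measurement is available that would explain this outcome.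

The three compounds leave open whether a carboxylic acid, a dimethylamino group or a morpholine on the same chain, or a longer chain between the sulfonyl sulfur and the amine, would give a step beyond the scatter. For the compounds shown here, they also leave open whether the same changes would stay within the scatter on a core other than the one shared by compound 1, compound 2 and compound 3.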